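Working notes on a small antiproliferative series

A few compounds are considered here, and "the series" means these few. Any claim that something is new, unique, unknown or untested is made for them only; others in the source may bear on it.

Measured so far:
compound 1 `OC[C@H]1O[C@@H](n2cnc3c(NCc4ccc(Cl)cc4Cl)ncnc32)[C@H](O)[C@@H]1O`: 128000 nM
compound 2 `COc1ccc(CNc2ncnc3c2ncn3C2OC(CO)[C@@H](O)[C@H]2O)c(O)c1`: "not determined" (no result reported)
compound 3 `COc1cc(O)cc(OC)c1CNc1ncnc2c1ncn2[C@@H]1O[C@H](CO)[C@@H](O)[C@H]1O`: > 166000 nM

Among the measured compounds shown here, in a functional assay on G-361 cells (Homo sapiens) for antiproliferative activity, with a stated time of 72 h (a lower number here means a stronger inhibitor, a higher number a weaker inhibitor), compound 1 gives 128000 nM, which is the only single number among the three entries, so compound 1 is the reference point of the set rather than a compound placed against others. For compound 3 this assay reports only a limit, > 166000 nM, not a number; the relevant note is the limit of > 166000 nM in this assay, at which 1 of the 3 values shown sits. Compound 2 carries no result in this assay, so it contributes nothing to the comparison. For the measured compounds named here, no pair of measured compounds differs in just one place, so no measured step is available to calibrate the change below.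

Compound 4 `OC[C@H]1O[C@@H](n2cnc3c(NCc4cccc(C(F)(F)F)c4)ncnc32)[C@H](O)[C@@H]1O` is the next candidate and differs from compound 1 in one place: 3-(trifluoromethyl)phenyl in place of 2,4-dichlorophenyl on a saturated chain carbon bound to a nitrogen on an aromatic ring. Both the leaving and the entering group are single six-membered aromatic rings of carbon only, without donors or acceptors, so the change is a swap of one halogenated aryl for another at the same place. Going by the values given here, with no measured step to lean on, the expectation is a step from compound 1 to compound 4 of a 1.1-fold higher number from compound 1 to compound 4 (0.04 log units; within the scatter), that is, no change beyond the usual scatter in either direction. Compound 4 is therefore estimated at 140000 nM, expected between 55000 nM and 350000 nM, with a real chance that this assay again returns only a limit.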

Compound 4, half-maximal inhibitory concentration: > 166000 nM
Compound 4 was reported as a limit; the forecaster's own chance of this, stated with the estimate: 40%; at least 1.1-fold (0.07 log units) between middle value and limit.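

In this assay compound 4 is reported only as a limit, > 166000 nM, not as a number. Among the compounds shown here, the replacement of 2,4-dichlorophenyl by 3-(trifluoromethyl)phenyl on a saturated chain carbon bound to a nitrogen on an aromatic ring gives the first measured step, an at least 1.2-fold higher number from compound 1 to compound 4 (0.11 log units; that floor lies within the scatter); it fixes only a floor, so this aryl swap shows no change beyond the usual scatter, and the true size of the step stays unknown. With this result, a second entry in the series rests at one and the same limit: the limit of > 166000 nM in this assay, at which 2 of the 4 values shown sit.

The compounds shown leave open how far compound 4 really lies from compound 1, and whether any group at this place can bring the number in this assay clearly below that of compound 1, 128000 nM. Both aryl groups compared here are carbon-only rings without donors or acceptors, so an aryl ring bearing an amine or a carboxylic acid, or a longer chain in place of the aryl group, remains the open question at this position.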